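The source may report more compounds than this note shows. Statements on the series, on what has been measured and on what is new or still open speak of the compounds shown alone.

Compound 1 `COc1cc2ncnc(Nc3ccc(Cl)c(C(F)(F)F)c3)c2cc1OCCCCC(=O)Nc1ccc(S(N)(=O)=O)cc1` gives 3910 nM in a functional assay on A-431 cells (Homo sapiens) for antiproliferative activity, read by MTT assay, with a stated time of 72 h; on this read-out lower numbers stand for stronger inhibition and higher numbers for weaker inhibition.
Compound 2 `COc1cc2ncnc(Nc3cccc(Cl)c3)c2cc1OCCCCC(=O)Nc1ccc(S(N)(=O)=O)cc1` gives 30400 nM.
Compound 3 `COc1cc2ncnc(Nc3cccc(C)c3)c2cc1OCCCCC(=O)Nc1ccc(S(N)(=O)=O)cc1` gives 7460 nM.

Compound 3 stands second highest of the three numbers: the step of a 1.9-fold higher number from compound 1 to compound 3 (0.28 log units; within the scatter) is within the scatter, while the step of a 4.1-fold lower number from compound 2 to compound 3 (0.61 log units; beyond the scatter) lies beyond it. Compound 4 `COc1cc2ncnc(Nc3ccccc3)c2cc1OCCCCC(=O)Nc1ccc(S(N)(=O)=O)cc1` differs from compound 3 by hydrogen in place of methyl on an aromatic carbon. Within the data shown here, no measured step removes a group to leave hydrogen at that position; the nearest guide is the step of a 4.1-fold lower number from compound 2 to compound 3 (0.61 log units; beyond the scatter), which shows that a small change at this position can shift the number modestly, and the step of a 1.9-fold higher number from compound 1 to compound 3 (0.28 log units; within the scatter), which hardly moved it. A small shift is therefore expected, of uncertain direction. Compound 4 is expected to give 10000 nM, within a range from 4000 nM to 25000 nM. The expected step of a 1.3-fold higher number from compound 3 to compound 4 (0.13 log units; within the scatter) is thus small.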

Compound 4, half-maximal inhibitory concentration: 25200 nM
Beside the measured number, compound 4's estimate is 2.5-fold (0.40 log units) below it; the whole stated range lies below it.
By their numbers in this assay, from the lowest: compounds 1 and 3 (each within the scatter of the next); then compounds 4 and 2 (each within the scatter of the next).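

In this assay, losing the methyl matters: the step is a 3.4-fold higher number from compound 3 to compound 4 (0.53 log units; beyond the scatter), so this small group counts at this place on the ring. Chloro and hydrogen cannot be told apart here (a 1.2-fold lower number from compound 2 to compound 4 (0.08 log units; within the scatter)), while the 4-chloro-3-(trifluoromethyl)phenyl group stays clearly ahead of phenyl (a 6.4-fold higher number from compound 1 to compound 4 (0.81 log units; beyond the scatter)). No supporting data explain why methyl and chloro differ at this position.

From the compounds shown here alone, whether a larger ethyl group would hold or extend the gain seen with methyl remains open. So does what an amine or a carboxylic acid on the same aromatic carbon would do.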